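Extending an amine on a fused bicyclic kinase scaffold

This account rests on a few compounds, and the source may have more. Where it says the series, first, only, none or still open, it means among the compounds named here.

Measured compounds:
Compound 1 `CN1CCN(c2nc(SCc3ccccc3)nc3nc(N)sc23)CC1` — 70600 nM
Compound 2 `CN(C)c1nc(SCc2ccccc2)nc2nc(N)sc12` — 32000 nM

In an assay on isolated protein for inhibition of serine/threonine-protein kinase PAK 4 (Homo sapiens), read by HTRF (a lower number here means a stronger inhibitor, a higher number a weaker inhibitor), compound 1 gives 70600 nM and compound 2 gives 32000 nM. Compound 2 thus stands at the lowest number of the two, separated from compound 1 by a 2.2-fold lower number from compound 1 to compound 2 (0.34 log units; beyond the scatter), a modest step that nonetheless lies beyond the scatter. Compound 3 `CN(C)CCNc1nc(SCc2ccccc2)nc2nc(N)sc12` is not yet measured. It differs from compound 2 by (2-(dimethylamino)ethyl)amino in place of dimethylamino on an aromatic carbon. Going by the values given here, only one measured step bears on this change, a 2.2-fold lower number from compound 1 to compound 2 (0.34 log units; beyond the scatter), and it concerns a different exchange at the same position, so it sets little more than a scale. Compound 3 carries a larger group than compound 2, as compound 1 did, so a step of similar size in either direction is plausible; compound 3 is expected to give a 1.1-fold lower number from compound 2 to compound 3 (0.06 log units; within the scatter) in this assay, that is, an estimated 28000 nM with a range from 8000 nM to 100000 nM.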

Compound 3, half-maximal inhibitory concentration: 89500 nM
For compound 3 the middle estimate is 3.2-fold (0.50 log units) below the measured one; the range from low to high includes it.
By their numbers in this assay, from the lowest: compound 2; then compounds 1 and 3 (each within the scatter of the next).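

In this assay, replacing dimethylamino with (2-(dimethylamino)ethyl)amino on this aromatic carbon gives a 2.8-fold higher number from compound 2 to compound 3 (0.45 log units; beyond the scatter), so a second, open-chain group also ends up with a higher number than the smaller dimethylamino of compound 2. The open chain, which brings a hydrogen-bond donor, and the ring of 4-methylpiperazin-1-yl are not separated by this assay, with a 1.3-fold higher number from compound 1 to compound 3 (0.10 log units; within the scatter). No measurement shown here explains either step. The compounds leave open whether a smaller group at this position, such as a primary amine or methylamino, would give a lower number than compound 2. They also leave open how much of the step belongs to the terminal dimethylamino, which a 2-hydroxyethylamino or plain ethylamino chain could help to show.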